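The compounds below may be only part of what the source reports. "The series", "measured", "known", "first", "only" and "open" are said of these compounds alone.

Going by the values given here, in a functional assay on A2780 cells (Homo sapiens) for inhibition, read by sulforhodamine B assay, with a stated time of 96 h (a higher number here means a weaker inhibitor of growth, a lower number a stronger inhibitor of growth), compound 2 (`CC[C@H](Nc1nc(NCc2ccccn2)c2ncn(C(C)C)c2n1)C(C)O`) gives 17000 nM, the only true number so far. Compound 1 (`CC[C@@H](Nc1nc(NCc2ccccn2)c2ncn(C(C)C)c2n1)C(O)C(C)(C)C`) gives > 50000 nM, which is a limit of the assay and not a number. Compound 3 (`CC[C@H](Nc1nc(NCc2ccccn2)c2ncn(C(C)C)c2n1)C(O)C(C)(C)C`) departs from compound 2 by tert-butyl in place of methyl on a saturated chain carbon bound to an oxygen on a saturated carbon and a saturated chain carbon, with tert-butyl in place of methyl on a saturated chain carbon bound to an oxygen. Among the compounds with values here, one measured step bears on this change, and it runs the opposite way, with 1-(1-hydroxyethyl)propyl replacing 1-ethyl-2-hydroxy-3,3-dimethylbutyl: an at least 2.9-fold lower number from compound 1 to compound 2 (0.46 log units; beyond the scatter). Read in reverse, that step from compound 1 points towards weaker growth inhibition, though it gives only a lower bound on size. The expected change is therefore modest and towards a higher number, a 2.1-fold higher number from compound 2 to compound 3 (0.31 log units; beyond the scatter). For compound 3 the estimated value is 35000 nM, with an expected range of 12000 nM to 80000 nM.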

Compound 3, concentration for 50% growth inhibition: > 50000 nM
Compound 3 ended at the assay's limit; the forecaster's own chance of this, stated with the estimate: 45%; at least 1.4-fold (0.15 log units) between middle value and limit.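

In this assay, tert-butyl in place of methyl on a saturated chain carbon bound to an oxygen gives an at least 2.9-fold higher number from compound 2 to compound 3 (0.46 log units; beyond the scatter), so the change is now read directly with the configuration drawn in compound 2, which the earlier step did not offer. Compound 3 gives > 50000 nM, a limit of the assay and not a number. The step from compound 1 to compound 3 cannot be read, because both compounds sit at the same limit: the limit of > 50000 nM in this assay, at which 2 of the 3 values shown sit.

Going by these compounds alone, whether the drawn configuration matters at this position stays open, and the only pair that isolates it offers no readable size: the fact that one of compounds 1 and 3 is drawn with a defined configuration and the other without, at the place where they differ Also open is how ethyl or isopropyl in place of methyl at this position would read in this assay, and where between methyl and tert-butyl the number rises.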